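Carbamoyl-to-sulfonyl exchange on the shared core

The compounds below may be only part of what the source reports. "The series", "measured", "known", "first", "only" and "open" are said of these compounds alone.

Of the compounds shown here, two have numbers so far. Compound 1 `Cn1c(=O)c(C(=O)Nc2ccc(F)cc2F)cc2cnc(Nc3ccc4[nH]ccc4c3)nc21` gives, in a functional assay on K562 cells (Homo sapiens) for inhibition, read by trypan blue exclusion, with a stated time of 72 h (a lower number here means a stronger inhibitor, a higher number a weaker inhibitor), 5000 nM, the lowest of the two numbers. Within the data shown here, compound 2 `O=c1[nH]c2nc(Nc3ccc4[nH]ccc4c3)ncc2cc1S(=O)(=O)c1ccc(F)cc1F` gives in this assay 15000 nM, a gap that lies beyond the scatter; no single step between compound 1 and compound 2 is counted, so the pair tells only that compound 2 sits at the higher number.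

Compound 3 `Cn1c(=O)c(S(=O)(=O)c2ccc(N)cc2F)cc2cnc(Nc3ccc4[nH]ccc4c3)nc21` is the next to be measured. Its difference from compound 1 is (4-amino-2-fluorophenyl)sulfonyl in place of (2,4-difluorophenyl)carbamoyl on an aromatic carbon. Among the measured compounds shown here, no measured pair isolates this exchange on the shared core, so the expectation rests on compound 1 alone.

The expected step is small and toward a higher number, a 1.6-fold higher number from compound 1 to compound 3 (0.20 log units; within the scatter), close to the edge of the scatter. Compound 3 is estimated at 8000 nM, with a range from 2000 nM to 30000 nM.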

Compound 3, half-maximal inhibitory concentration: 1500 nM
Beside the measured number, compound 3's estimate is 5.3-fold (0.73 log units) above it; measured number below the stated range.
By their numbers in this assay, from the lowest: compound 3; then compound 1; then compound 2.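

In this assay, the exchange of (2,4-difluorophenyl)carbamoyl for (4-amino-2-fluorophenyl)sulfonyl on this aromatic carbon gives a 3.3-fold lower number from compound 1 to compound 3 (0.52 log units; beyond the scatter), the first single-place step readable in the series. The position therefore accepts a sulfonyl-linked aryl group in place of the carbamoyl-linked one, and the number falls rather than rises. Nothing measured accounts for the size or direction of this step.

The change alters the link and the ring substituents together, so the share of each in the step stays unresolved; (4-amino-2-fluorophenyl)carbamoyl or (2,4-difluorophenyl)sulfonyl on the core of compound 1 would separate them. Also open, from the compounds shown here alone, is whether the amino group itself matters, which an acetamido or methylamino group at that ring carbon would test.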